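The source may hold more compounds than are shown below. What is called first, only, known or untested is meant among the compounds shown, and "the series" means these compounds.

Measured so far in a functional assay on DU-145 cells (Homo sapiens) for inhibition, read by MTT assay, with a stated time of 24 h; on this read-out higher numbers stand for weaker inhibition and lower numbers for stronger inhibition:
compound 1 `CCOC(=O)C1=Cc2ccccc2OC1(OCc1cn(-c2ccc(F)cc2)nn1)C(F)(F)F` gives 8900 nM;
compound 2 `O=C(O)C1=Cc2ccccc2OC1(OCc1cc(-c2ccc(F)cc2)no1)C(F)(F)F` gives 168000 nM;
compound 3 `CCOC(=O)C1=Cc2ccccc2OC1(OCc1cn(-c2ccc(C)cc2)nn1)C(F)(F)F` gives 30200 nM.

Compound 3 stands second highest of the three numbers in this assay. Among the measured compounds shown here, its nearest neighbour is compound 1, reached through the one measured step, a 3.4-fold higher number from compound 1 to compound 3 (0.53 log units; beyond the scatter), which is modest but beyond the scatter. Compound 2 lies furthest away with a higher number still, but it differs from compound 3 in more than one place, so only its value can be set beside that of compound 3.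

Compound 4 `CCOC(=O)C1=Cc2ccccc2OC1(OCc1cn(CC(=O)Nc2ccc(C)cc2)nn1)C(F)(F)F` differs from compound 3 in a single place: ((4-methylphenyl)carbamoyl)methyl in place of 4-methylphenyl on an aromatic nitrogen.

For the measured compounds named here, no measured step bears directly on this change. Going by the values given here, the one step available concerns the six-membered ring of carbon only, not the group on the aromatic nitrogen of the five-membered ring with three nitrogens, so it gives no direction for the new substituent. With nothing to point up or down, no step beyond the scatter is expected in this assay, and the estimated step of a 1.0-fold lower number from compound 3 to compound 4 (0.00 log units; within the scatter) is taken as flat. Compound 4 is therefore expected to give about 30000 nM, within a range from 8000 nM to 120000 nM.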

Compound 4, half-maximal inhibitory concentration: > 150000 nM
Compound 4 was reported as a limit; the forecaster's own chance of this, stated with the estimate: 10%; middle value at least 5.0-fold (0.69 log units) from the limit.
By their numbers in this assay, from the lowest: compound 1; then compound 3; then compound 2.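

In this assay, compound 4 sits at a limit and not at a number: the limit of > 150000 nM in this assay, at which 1 of the 4 values shown sits.

Going by these compounds, putting ((4-methylphenyl)carbamoyl)methyl in place of 4-methylphenyl on the aromatic nitrogen gives an at least 4.9-fold higher number from compound 3 to compound 4 (0.69 log units; beyond the scatter), and putting it in place of 4-fluorophenyl gives an at least 16-fold higher number from compound 1 to compound 4 (1.22 log units; beyond the scatter); both steps point towards weaker inhibition, and their true sizes stay unknown. The earlier step changed only a substituent on the six-membered aromatic ring of carbon, whereas these two show that the group attached directly to the aromatic nitrogen can also shift the number beyond the scatter, even though the entering group still carries the same 4-methylphenyl ring as the group that leaves compound 3.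

The entering group changes several things at once, so the compounds shown do not separate the contribution of the carbonyl and the amide hydrogen from that of the longer chain that sets the aromatic ring further from the nitrogen. On these data alone, a plain benzyl group, an ether-linked chain or a chain ending in an amine on this nitrogen would be needed to tell these apart, and whether any group here gives a lower number than compound 1 remains open.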